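The compounds below may be only part of what the source reports. "The series", "measured", "known", "first", "only" and "open" are said of these compounds alone.

Compound 1 `CSc1ccc2c(Cc3cccc(C(=O)O)n3)c(-c3ccccc3)nn2c1`: 87 nM in a functional assay on cells for antagonist activity at prostaglandin E2 receptor EP1 subtype (Rattus norvegicus), read by fluorescence and calcium flux, with a stated time of 60 s; on this read-out higher numbers stand for weaker inhibition and lower numbers for stronger inhibition
Compound 2 `O=C(O)c1cccc(Cc2c(-c3cccc(Cl)c3)nn3cc(Cl)ccc23)n1`: 480 nM in this assay

Of the compounds shown here, two sharing one core have been measured in this assay. Compound 1 gives 87 nM, and compound 2 gives 480 nM, which is the higher of the two numbers; the gap between compound 1 and compound 2 lies beyond the usual scatter of such measurements, so compound 2 inhibits less strongly than compound 1.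

The account now turns to compound 3 `O=C(O)c1cccc(Cc2c(C3CCCCC3)nn3cc(Cl)ccc23)n1`, which has not yet been measured in this assay. Compound 3 differs from compound 2 in one place: cyclohexyl in place of 3-chlorophenyl on an aromatic carbon

For the measured compounds named here, no measured pair shows what such a change does on this core, so any expectation rests on compound 2 alone. Compound 3 is estimated to sit in the weaker direction, with a step of a 1.9-fold higher number from compound 2 to compound 3 (0.27 log units; within the scatter) from its parent expected in this assay, a step of modest size that may yet fall within the scatter. Compound 3 is therefore expected to give about 900 nM in this assay, with a likely range from 250 nM to 3500 nM.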

Compound 3, half-maximal inhibitory concentration: 1200 nM
Estimate against measurement, compound 3: 1.3-fold (0.12 log units) below; the range from low to high includes it.
By their numbers in this assay, from the lowest: compound 1; then compound 2; then compound 3.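

For the compounds shown here, the pair gives the first direct reading of this position, the aromatic carbon of the five-membered aromatic ring with 2 nitrogen: in this assay, a 2.5-fold higher number from compound 2 to compound 3 (0.40 log units; beyond the scatter), a modest loss of inhibition that lies beyond the scatter. The position therefore responds to what it carries, yet inhibition remains measurable with a non-aromatic cyclohexyl ring, so an aromatic ring is not required here for compound 3 to register in this read-out. The change swaps the aromatic ring for a non-aromatic one and removes the chlorine in the same step, and no information is available that would explain the loss of inhibition.

On these data alone, the two parts of the change cannot be separated with these compounds, so it remains open how much of the step belongs to the chlorine and how much to the ring. As far as these compounds go, it is also open how this position would respond to a cyclopentyl ring, a morpholine ring or an open chain such as butyl, and whether the step would look the same on another substitution of the shared core.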